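The source may hold more compounds than are shown below. What is called first, only, known or untested is meant among the compounds shown, and "the series" means these compounds.

Of the compounds shown here, three have been measured in an assay on NK92 cells for inhibition of interleukin-15 (Homo sapiens), read by AlphaScreen, with stated times of 30 min and 1 h; on this read-out higher numbers stand for weaker inhibition and lower numbers for stronger inhibition. Compound 1 `CCOC(CCn1c(Cc2nn(C)c(=O)c3ccccc23)nnc1SCC(=O)Nc1ccc(Cl)cc1Cl)OCC` gives a value that is a limit of the assay rather than a number, > 30000 nM. Compound 2 `CN(C)CCCn1c(Cc2nn(C)c(=O)c3ccccc23)nnc1SCCCCCCCC(=O)Nc1ccc(Cl)cc1Cl` likewise reaches only a limit, > 30000 nM. Compound 3 `Cn1c(Cc2nn(CCCO[Si](C)(C)C(C)(C)C)c(=O)c3ccccc23)nnc1SCCCCCCCC(=O)Nc1ccc(Cl)cc1Cl` also sits at a limit, > 30000 nM. Where compound 3 stands is thus known only as a bound, not as a number, and the other two stand no differently. All three sit at the limit of > 30000 nM in this assay, at which 3 of the 3 values shown sit.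

Compound 4 `Cn1c(Cc2n[nH]c(=O)c3ccccc23)nnc1SCCCCCCCC(=O)Nc1ccc(Cl)cc1Cl` differs from compound 3 in one place: a hydrogen atom in place of a group of 11 heavy atoms (9 carbon, 1 oxygen, 1 silicon; no ring), on an aromatic nitrogen. Within the data shown here, no pair of measured compounds differs in a single place, so no measured step guides the expectation. For compound 4 the expected step is none beyond the scatter, a number no higher from compound 3 to compound 4 (the limit leaves the size open). Compound 4 is accordingly estimated at 30000 nM, with a range from 8000 nM to 100000 nM, and most likely this assay will again report only a limit.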

Compound 4, half-maximal inhibitory concentration: 20000 nM
Compound 4: middle estimate off by 1.5-fold (0.18 log units), on the high side; low and high end bracket the measured number.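

Replacing the group of 11 heavy atoms on the aromatic nitrogen with a hydrogen atom gives an at least 1.5-fold lower number from compound 3 to compound 4 (0.17 log units; that floor lies within the scatter). In this assay compound 4 gives 20000 nM, so this nitrogen can carry a hydrogen atom and still yield a measured number rather than a limit. Compound 3 gives only a limit, > 30000 nM, so the true size of this step stays unknown, and the limit is shared across the series: the limit of > 30000 nM in this assay, at which 3 of the 4 values shown sit.

On these data alone, it remains open whether a shorter group on this nitrogen, such as an ethyl group, would give a measurable number too. A chain on the same nitrogen ending in a free hydroxyl, an amine or a carboxylic acid, in place of the silicon-bearing end of compound 3, is equally untested in the compounds shown.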